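A few compounds are considered here, and "the series" means these few. Any claim that something is new, unique, unknown or untested is made for them only; others in the source may bear on it.

Measured so far:
- compound 1, `CC1(C[C@@H](O)C(=O)N2[C@@H]3C[C@@H]3C[C@H]2C(=O)NCc2cc(Cl)ccc2-n2cnnn2)CC1`: 1300 nM
- compound 2, `CC(C)(C)C[C@@H](O)C(=O)N1C[C@@H]2C[C@@H]2[C@H]1C(=O)NCc1cc(Cl)ccc1-n1cnnn1`: 910 nM
- compound 3, `CC(C)CC[C@@H](O)C(=O)N1N=CC[C@H]1C(=O)NCc1cc(Cl)ccc1-n1cnnn1`: 630 nM

All three numbers come from a functional assay on a cell-free system (plasma, Homo sapiens), with a stated time of 3 min; a lower number here means a stronger inhibitor, a higher number a weaker inhibitor. Among them compound 1 carries the highest number. Its nearest neighbour is compound 2, whose value in this assay lies within the scatter of the value of compound 1, so no order between these two can be claimed. Compound 3 gives the lowest number, and its gap to compound 1 lies just beyond the scatter; compound 3 also differs from compound 1 in the core, so the side-chain and core contributions cannot be separated.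

The step under consideration leads from compound 1 to compound 4, `CC(C)(C)[C@@H](O)C(=O)N1[C@@H]2C[C@@H]2C[C@H]1C(=O)NCc1cc(Cl)ccc1-n1cnnn1`, which keeps the core of compound 1 and changes only the side chain:
tert-butyl in place of (1-methylcyclopropyl)methyl on a saturated chain carbon bound to a carbonyl carbon and an oxygen on a saturated carbon

Among the compounds with values here, no measured pair shows this change in isolation. The side chain loses one carbon and its three-membered ring and becomes the shorter tert-butyl branch. With nothing in the measured set to anchor the direction, the expected step in this assay is small, within the scatter, with a slight lean toward a higher number; the expected step is a 1.2-fold higher number from compound 1 to compound 4 (0.06 log units; within the scatter). Compound 4 is estimated at 1500 nM, with a range from 600 nM to 4000 nM.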

Compound 4, half-maximal inhibitory concentration: 1100 nM
Compound 4: the middle estimate sits 1.4-fold (0.13 log units) above what was measured; the range from low to high includes it.
By their numbers in this assay, from the lowest: compounds 3, 2, 4 and 1 (each within the scatter of the next, the first and the last beyond it).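

In this assay, within the data shown here, tert-butyl in place of (1-methylcyclopropyl)methyl on a saturated chain carbon bound to a carbonyl carbon and an oxygen on a saturated carbon gives a 1.2-fold lower number from compound 1 to compound 4 (0.07 log units; within the scatter); this is the first step that holds the core of compound 1 fixed and differs only in the side chain, which the earlier compounds, all differing in the core as well, could not provide. On this core, the side chain can go from 5 heavy atoms with a three-membered ring to 4 heavy atoms with no ring while the two values lie within the scatter of each other. No measurement at hand accounts for this result.

Both groups compared are all-carbon, so a primary amine, a carboxylic acid or a phenyl ring at this place would test something that this pair cannot. On these data alone, whether tert-butyl gives a similar number on the cores of compound 2 and compound 3 also remains open.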